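The source may report more compounds than this note shows. Statements on the series, on what has been measured and on what is new or still open speak of the compounds shown alone.

Compound 1 `COc1ccccc1CNc1ncnc2c1ncn2C1CCCCO1` is the starting point of a small set of four compounds built on one shared core. In an ADME assay on K562 cells (Homo sapiens) for cytotoxicity, with a stated time of 72 h (a lower number here means a stronger inhibitor, a higher number a weaker inhibitor), compound 1 gives 97000 nM. Compound 2 `COc1ccc(CNc2ncnc3c2ncn3C2CCCCO2)c(OC)c1` arises from compound 1 through (methoxy in place of hydrogen on an aromatic carbon). In this assay compound 2 gives only a limit, > 25000 nM. The step that the limit leaves unreadable from compound 1 to compound 2 is therefore unreadable in size. Compound 3 `COc1cc(CNc2ncnc3c2ncn3C2CCCCO2)cc(OC)c1` differs from compound 1 in more than one place, and the difference between the two cores is not broken down here. In this assay compound 3 likewise gives only a limit, > 100000 nM. Compound 4 `COc1cc(CNc2ncnc3c2ncn3C2CCCCO2)cc(OC)c1OC` is not yet measured in this assay; it arises from compound 3 through (methoxy in place of hydrogen on an aromatic carbon), the same kind of change as that from compound 1 to compound 2, though here the entering group sits ortho to two methoxy groups rather than meta to a methoxy group. The expected step of a number no higher from compound 3 to compound 4 (the limit leaves the size open) in this assay rests on the limit given by compound 3, > 100000 nM. Compound 4 is estimated in this assay at 100000 nM, between 30000 nM and 300000 nM.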

Compound 4, half-maximal inhibitory concentration: > 100000 nM
Compound 4 ended at the assay's limit; the forecaster's own chance of this, stated with the estimate: 70%; the middle value lies on the limit itself.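

Going by these compounds alone, compound 3 and compound 4 both stand only at limits in this assay, so no step between them can be read. The compounds shown leave open how large any effect of methoxy in place of hydrogen is on the shared core.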